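This account rests on a few compounds, and the source may have more. Where it says the series, first, only, none or still open, it means among the compounds named here.

Series notes. The shared core is that of compound 1 `CCOC(=O)C12C(=O)OCC=C1COC2c1ccccc1`. In a functional assay on QGY cells (Homo sapiens) for cytotoxicity, read by MTT assay (a higher number here means a weaker inhibitor, a lower number a stronger inhibitor), compound 1 gives only a limit, > 1000000 nM. Compound 2 `CCOC(=O)C12C(=O)OCC=C1COC2c1ccc(C(C)(C)C)cc1` gives only a limit in this assay as well, > 1000000 nM. Compound 3 `CCOC(=O)C12C(=O)OCC=C1COC2c1ccc(OC)cc1` likewise gives only a limit in this assay, > 1000000 nM. All three values sit at the limit of > 1000000 nM in this assay, at which 3 of the 3 values shown sit, so the steps a step that the two limits leave unreadable from compound 1 to compound 2, a step that the two limits leave unreadable from compound 1 to compound 3 and a step that the two limits leave unreadable from compound 2 to compound 3 cannot be sized. Compound 4 `CCOC(=O)C12C(=O)OCC=C1COC2c1ccc(N(C)C)cc1` carries the change (dimethylamino in place of methoxy on an aromatic carbon). Among the compounds with values here, no measured step bears readably on this change, so the expected step of a number no higher from compound 3 to compound 4 (the limit leaves the size open) in this assay can only be anchored to the shared limit. Compound 4 is expected in this assay at 1000000 nM, with a range from 200000 nM to 5000000 nM, most likely reported again as a limit only.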

Compound 4, half-maximal inhibitory concentration: > 1000000 nM
Compound 4: a limit, no number (the forecaster's own chance of this, stated with the estimate: 85%); the middle value lies on the limit itself.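

In this assay, within the data shown here, all four values are limits, so no step from compound 1, compound 2 or compound 3 to compound 4 can be read. The compounds shown leave open whether any change on the aromatic ring would give a readable number.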